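Shifting a Methyl Around a Pyridyl Sulfonamide

The source may report more compounds than this note shows. Statements on the series, on what has been measured and on what is new or still open speak of the compounds shown alone.

Compound 3 `Cc1ccc(S(=O)(=O)N(CC(=O)NCc2ccc(Cl)cc2)c2cccnc2C)cc1` gives 200 nM in an assay on CHO cells for displacement of a labelled ligand from prostaglandin E2 receptor EP1 subtype (Homo sapiens) (on this read-out lower numbers stand for stronger inhibition and higher numbers for weaker inhibition), the highest of the two numbers reported, with compound 1 `CCc1ccccc1N(CC(=O)NCc1ccc(Cl)cc1)S(=O)(=O)c1ccc(C)cc1` at 10 nM. Compound 2 `Cc1ccc(S(=O)(=O)N(CC(=O)NCc2ccc(Cl)cc2)c2ccccn2)cc1` reaches only the limit of < 1000 nM in this assay. Among these three the only readable step is a 20-fold higher number from compound 1 to compound 3 (1.30 log units; beyond the scatter); the steps a step that the limit leaves unreadable from compound 1 to compound 2 and a step that the limit leaves unreadable from compound 2 to compound 3 cannot be sized because of the limit of < 1000 nM in this assay, at which 1 of the 3 values shown sits. Compound 4 `Cc1ccc(S(=O)(=O)N(CC(=O)NCc2ccc(Cl)cc2)c2ccc(C)nc2)cc1` differs from compound 3 by 6-methylpyridin-3-yl in place of 2-methylpyridin-3-yl on a sulfonamide nitrogen. Among the compounds with values here, no measured pair tests a methyl moved from one position of the same ring to another, so the only step bearing on this change is the large loss in a 20-fold higher number from compound 1 to compound 3 (1.30 log units; beyond the scatter), which shows that the group on the sulfonamide nitrogen is sensitive ground in this assay. Compound 4 is expected to give a somewhat higher number, a 2.5-fold higher number from compound 3 to compound 4 (0.40 log units; beyond the scatter), with an estimate of 500 nM and a range from 100 nM to 3000 nM.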

Compound 4, inhibition constant: < 1000 nM
Compound 4 gave a limit, no number (the forecaster's own chance of this, stated with the estimate: 20%); the middle value does not contradict the limit.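

Compound 4 gives < 1000 nM in this assay as a limit, not a number. Within the data shown here, no step to compound 4 from compound 1, compound 2 or compound 3 can be read: the limit of < 1000 nM in this assay, at which 2 of the 4 values shown sit.

From the compounds shown here alone, whether 6-methylpyridin-3-yl and 2-methylpyridin-3-yl on the sulfonamide nitrogen truly differ in this assay remains open.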